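This account rests on a few compounds, and the source may have more. Where it says the series, first, only, none or still open, it means among the compounds named here.

Going by the values given here, compound 3 `Cc1ccc2[nH]c(CC(CC(=O)O)c3ccc(Cl)cc3)nc2c1` stands lowest among the three compounds measured so far. In an assay on isolated protein for inhibition of protein kinase C zeta type (Homo sapiens), read by 33P incorporation, tested at 200 uM (on this read-out lower numbers stand for a weaker effect and higher numbers for a stronger effect at the one concentration tested), compound 3 gives 0%, whereas compound 1 `O=C(O)CC(Cc1nc2cc(Br)ccc2[nH]1)c1ccc(Cl)cc1` gives 80% and compound 2 `O=C(O)CC(Cc1nc2cc(C(F)(F)F)ccc2[nH]1)c1ccc(Cl)cc1` gives 85%. Two large steps lead down to this value: a number 80 percentage points lower from compound 1 to compound 3 (beyond the scatter) and a number 85 percentage points lower from compound 2 to compound 3 (beyond the scatter). The remaining step is small: a number 5 percentage points higher from compound 1 to compound 2 (within the scatter).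

Compound 4 `N#Cc1ccc2[nH]c(CC(CC(=O)O)c3ccc(Cl)cc3)nc2c1` differs from compound 3 in one place: cyano in place of methyl on an aromatic carbon. Among the compounds with values here, no measured step involves a cyano group, so the expectation rests on the two steps in which methyl replaced another group on the same aromatic carbon. Both bromo and trifluoromethyl at this position went with strong inhibition, while methyl went with none, so methyl appears to be the unfavourable choice among the three groups tested. Cyano is a further group that is not methyl; if it behaves like bromo and trifluoromethyl, most of the inhibition should return, but with only three measured compounds this is far from certain. Compound 4 is therefore expected to give 60% in this assay, with a range from 20% to 90%. The expected step is a number 60 percentage points higher from compound 3 to compound 4 (beyond the scatter).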

Compound 4, a percentage reported as inhibition, at one concentration (the size of the read-out at that concentration, not a potency): 0%
Beside the measured number, compound 4's estimate is 60 percentage points above it, and the stated range ends above it.
By their numbers in this assay, from the lowest: compounds 3 and 4 (each within the scatter of the next); then compounds 1 and 2 (each within the scatter of the next).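

Cyano in place of methyl on this aromatic carbon gives no change at the digits printed from compound 3 to compound 4 (within the scatter) in this assay, so methyl is no longer the only group here that goes with a complete lack of inhibition. Cyano in place of bromo gives a number 80 percentage points lower from compound 1 to compound 4 (beyond the scatter) and cyano in place of trifluoromethyl gives a number 85 percentage points lower from compound 2 to compound 4 (beyond the scatter), which splits the four groups at this one position into two clear pairs: bromo and trifluoromethyl with strong inhibition, methyl and cyano with none. The data available here offer no explanation of what separates these two pairs.

Which pair other groups on the same carbon would join remains open, for example fluoro, methoxy or an amine, and a group of that kind could also show whether inhibition at this position is all or nothing or can take values in between. As far as these compounds go, each compound is also described at only one concentration, so how strong the effect of compounds 1 and 2 would be at lower concentrations, and whether compounds 3 and 4 would show any inhibition at a higher concentration, also stays unknown.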